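The source may hold more compounds than are shown below. What is called first, only, known or untested is meant among the compounds shown, and "the series" means these compounds.

Compound 1 `COc1cccc(CNCc2c(C(=O)O)n(Cc3ccc(O)cc3)c3cc(C(C)C)ccc23)c1`: > 50000 nM (a limit)
Compound 2 `COc1cccc(CNCc2c(C(=O)O)n(Cc3ccc(C)cc3)c3cc(C(C)C)ccc23)c1`: 4550 nM

For the measured compounds named here, in a functional assay on Bel7402/5-FU cells (Homo sapiens) for antiproliferative activity, read by MTT assay, with a stated time of 72 h (a higher number here means a weaker inhibitor, a lower number a stronger inhibitor), compound 2 gives 4550 nM, the only true number so far. Compound 1 gives > 50000 nM, which is a limit of the assay and not a number.

Compound 3 `COc1cccc(CNCc2c(C(=O)O)n(Cc3ccc(N)cc3)c3cc(C(C)C)ccc23)c1` keeps all of compound 2 except one group: amino in place of methyl on an aromatic carbon. Going by the values given here, only one measured step bears on this change, and it is large: an at least 10-fold lower number from compound 1 to compound 2 (1.04 log units; beyond the scatter). That step put methyl in place of hydroxy on the same carbon. The entering amino, a hydrogen-bond donor, undoes the methyl, so the expected direction in this assay is towards a higher number, a weaker inhibitor. With a single step as a guide, the size is uncertain, and a moderate change is expected: a 3.1-fold higher number from compound 2 to compound 3 (0.49 log units; beyond the scatter). For compound 3 the estimate is 14000 nM, with an expected range from 4000 nM to 50000 nM.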

Compound 3, half-maximal inhibitory concentration: > 50000 nM
Compound 3 gave a limit, no number (the forecaster's own chance of this, stated with the estimate: 25%); middle value at least 3.5-fold (0.55 log units) from the limit.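

On this carbon of the benzyl group, amino behaves like hydroxy and not like methyl: in this assay the change is large, an at least 10-fold higher number from compound 2 to compound 3 (1.04 log units; beyond the scatter). Of the three groups shown here, only methyl gives a true number, so the loss seen with hydroxy is no longer a single case. The step between compound 1 and compound 3 cannot be read, as each ends in a limit and not a number: the limit of > 50000 nM in this assay, at which 2 of the 3 values shown sit.

Still open, as far as these compounds go, is whether methyl itself matters or whether other groups on this carbon would do as well, such as ethyl, chlorine, methoxy or plain hydrogen. The compounds shown also give no step at any other place on the shared core, so the reach of this result beyond this one carbon is unknown.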